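Half-life notes: 1-methylpiperidin-2-yl to 1-methylpiperidin-3-yl

The compounds below may be only part of what the source reports. "The series", "measured", "known", "first", "only" and "open" are said of these compounds alone.

Of the compounds shown here, two have so far been read in an ADME assay on microsomes from liver (Mus musculus) for metabolic stability, read by LC-MS, using NADPH, with stated times of 15 min and 60 min, tested at 4.6 uM; a lower number here means that the compound disappears faster, a higher number that the compound lasts longer. Compound 1 `CC(C)N1CCC(c2ccc3c(c2)oc(=O)n3C(=O)NCCCCc2ccccc2)CC1` gives 1 h. Compound 2 `CC(C)CNC(=O)n1c(=O)oc2cc(C3CCCCN3C)ccc21` gives 0.25 h, the lower of the two numbers, and the gap to compound 1 lies beyond the usual scatter. These two compounds differ in more than one place, so their gap cannot be assigned to any single group.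

Compound 3 `CC(C)CNC(=O)n1c(=O)oc2cc(C3CCCN(C)C3)ccc21` has the same atoms as compound 2, joined differently: 1-methylpiperidin-3-yl in place of 1-methylpiperidin-2-yl on an aromatic carbon. For the measured compounds named here, no measured pair shows what this kind of change does. The expectation therefore starts from compound 2 at 0.25 h, its closest structural reference, and compound 1 at 1 h gives only a loose guide to the upper end. The expected move in this assay is slightly upward and no larger than the scatter, estimated as a 1.6-fold higher number from compound 2 to compound 3 (0.20 log units; within the scatter). For compound 3 the estimated half-life is 0.4 h, with an expected range of 0.2 h to 1 h.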

Compound 3, half-life: > 1 h
Compound 3: a limit, no number; the forecaster's own chance of this, stated with the estimate: 15%; middle value at least 2.5-fold (0.39 log units) from the limit.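

In this assay, joining the ring as 1-methylpiperidin-3-yl in place of 1-methylpiperidin-2-yl gives an at least 4.0-fold higher number from compound 2 to compound 3 (0.60 log units; beyond the scatter). For the compounds shown here, this is the first step that changes one place only, and it shows that, on this aromatic carbon, meta to a fused ring and para to a fused ring, the half-life depends on how the piperidine is joined, even with the same atoms and the same counts of donors and acceptors. Compound 3 gives > 1 h, which is a limit of the assay and not a number, so the step marks a lower bound on the change and its full size stays unread, with one value in the set capped in this way: the limit of > 1 h in this assay, at which 1 of the 3 values shown sits.

Still open, from the compounds shown here alone, is whether 1-methylpiperidin-4-yl, or a piperidin-3-yl with hydrogen in place of the methyl on nitrogen, would read as high as compound 3 at this place. Going by these compounds alone, also open is whether the same change of attachment would carry the same gain on a core bearing the longer chain of compound 1, since no single-place step yet speaks to that chain.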